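This account rests on a few compounds, and the source may have more. Where it says the series, first, only, none or still open, it means among the compounds named here.

Measured compounds:
compound 1, `O=Cc1ccc(-c2cn3ccnc3c(-c3ccc4ncn(C5CCCCC5)c4c3)n2)cc1`, 16.5%
compound 2, `O=Cc1ccc(-c2cn3ccnc3c(-c3ccc4ncn(Cc5ccccc5)c4c3)n2)cc1`, 16.5%
compound 3, `c1cn2cc(-c3ccc4c(c3)ncn4C3CCCCC3)nc(-c3ccc4ncn(C5CCCCC5)c4c3)c2n1`, 30%

All three were tested in a functional assay on HL-60 cells (Homo sapiens) for inhibition, read by sulforhodamine B assay, with a stated time of 48 h, tested at 10 uM; a higher number here means more inhibition at the concentration tested (going by the name of the read-out), a lower number less inhibition. Compound 1 and compound 2 differ by one change, (benzyl in place of cyclohexyl on an aromatic nitrogen), and that change made a step of no change at the digits printed from compound 1 to compound 2 (within the scatter). Compound 3 carries a different core; the difference between the two cores is not broken down here. In this assay compound 3 gives 30%, which stands apart from compound 1 and compound 2.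

Compound 4, `c1ccc(Cn2cnc3ccc(-c4nc(-c5ccc6c(c5)ncn6C5CCCCC5)cn5ccnc45)cc32)cc1`, has not yet been measured. It arises from compound 3 by benzyl in place of cyclohexyl on an aromatic nitrogen, the same change as from compound 1 to compound 2, at the same kind of place. The step is expected to be no change at the digits printed from compound 3 to compound 4 (within the scatter), because the earlier step was no change at the digits printed from compound 1 to compound 2 (within the scatter). Compound 4 is therefore estimated at 30%, between 16% and 44%.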

Compound 4, a percentage reported as inhibition, at one concentration (the size of the read-out at that concentration, not a potency): -20.8%
Compound 4: the middle estimate sits 50.8 percentage points above what was measured, and the stated range ends above it.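

Benzyl in place of cyclohexyl on an aromatic nitrogen gave a number 50.8 percentage points lower from compound 3 to compound 4 (beyond the scatter) in this assay. The size of this step therefore did not carry over from one core to the other: the same change on two cores in this assay, no change at the digits printed (within the scatter) from compound 1 to compound 2 and a number 50.8 percentage points lower (beyond the scatter) from compound 3 to compound 4, 50.8 percentage points apart, beyond the scatter of two such steps. Among these compounds, this shows that the step seen on one core is a poor guide to the step on the other, but with only two cores it gives no rule for a further core and does not show which part of the cores matters.

Still open, on these data alone, is how other groups on that nitrogen would behave on either core, such as methyl, a longer chain or a chain ending in an amine.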